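The source may report more compounds than this note shows. Statements on the series, on what has been measured and on what is new or still open speak of the compounds shown alone.

Measured so far:
compound 1 `CC(=O)Nc1cc2c(C3CCN(C)CC3)c[nH]c2cn1` — 39 nM
compound 2 `Cc1cccc(C(=O)Nc2ccc3[nH]cc(C4CCN(C)CC4)c3n2)c1` — 490 nM
compound 3 `CC(=O)Nc1ncc2[nH]cc(C3CCN(C)CC3)c2n1` — 470 nM

In an assay for binding affinity to 5-hydroxytryptamine receptor 1D (Homo sapiens), read by radioligand binding (on this read-out higher numbers stand for weaker inhibition and lower numbers for stronger inhibition), compound 2 gives 490 nM, the highest number among the three compounds measured. Compound 3, with 470 nM, stands within the usual scatter of compound 2, so the two cannot be told apart on this read-out. Compound 1, with 39 nM, lies well beyond the scatter and marks the low end of the set; compound 2 is thus separated from compound 1 by a clear gap, and from compound 3 by none.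

The next compound, compound 4 `CN1CCC(c2c[nH]c3ccc(NC(=O)Nc4ccc(F)cc4)nc23)CC1`, is reached from compound 2 by a single change: (4-fluorophenyl)amino in place of 3-methylphenyl on a carbonyl carbon. Among the compounds with values here, no pair of measured compounds shares this change, so the size of the step can only be guessed. The only hint from the measured set is that compound 1, carrying the smallest acyl group, gives the lowest number, while the larger aromatic acyl group of compound 2 sits at the high end; compound 4 keeps an aromatic ring on the carbonyl, with an amino link and a fluorine added. The expected step from compound 2 to compound 4 is therefore a 1.6-fold lower number from compound 2 to compound 4 (0.21 log units; within the scatter), a mild move toward lower numbers that may well stay within the scatter. Compound 4 is estimated at 300 nM, in the range 80 nM to 1200 nM.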

Compound 4, inhibition constant: 3.8 nM
Compound 4: middle estimate off by 79-fold (1.90 log units), on the high side; measured number below the stated range.
By their numbers in this assay, from the lowest: compound 4; then compound 1; then compounds 3 and 2 (each within the scatter of the next).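

In this assay the change of (4-fluorophenyl)amino in place of 3-methylphenyl on a carbonyl carbon gives a 130-fold lower number from compound 2 to compound 4 (2.11 log units; beyond the scatter) and so shows that this place can move the number strongly through a single substitution. Both groups carry one six-membered aromatic ring of carbon only, so having such a ring on the carbonyl does not by itself set the number; the entering group differs in its nitrogen, with one hydrogen-bond donor, and its fluorine, and the leaving group has a methyl. Nothing measured here accounts for the size of this step.

Within the data shown here, the single pair does not separate the amino link from the fluorine, and the ring substitution also changes with it, so phenylamino without fluorine and phenoxy on the same carbonyl are the direct questions at this place. Also open is whether the same (4-fluorophenyl)amino group gives a step of similar size on the core of compound 1 or the core of compound 3, since neither core is shown carrying anything but the small acetyl-type amide.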